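A few compounds are considered here, and "the series" means these few. Any claim that something is new, unique, unknown or untested is made for them only; others in the source may bear on it.

Measured in a functional assay on I10 cells (Mus musculus) for inhibition, read by MTT assay, with a stated time of 72 h; a lower number here means a stronger inhibitor, a higher number a weaker inhibitor:
- Compound 1 `C=CCc1ccc(OCc2c(Cl)cccc2Cl)c(-c2ccc(OCc3c(Cl)cccc3Cl)c(CC=C)c2)c1`: > 50000 nM (a limit, not a number)
- Compound 2 `C=CCc1ccc(O)c(-c2ccc(OCc3ccccc3)c(CC=C)c2)c1`: 29800 nM
- Compound 3 `C=CCc1ccc(OCc2ccc(Cl)c(Cl)c2)c(-c2ccc(OCc3ccc(Cl)c(Cl)c3)c(CC=C)c2)c1`: > 50000 nM (a limit, not a number)

Compound 2 is the only one of the three with a true number, at 29800 nM. The other two compounds sit at the limit of > 50000 nM in this assay, at which 2 of the 3 values shown sit. The next compound, compound 4 `C=CCc1ccc(O)c(-c2ccc(OCc3c(Cl)cccc3Cl)c(CC=C)c2)c1`, keeps the rest of compound 2 and changes one group: 2,6-dichlorophenyl in place of phenyl on a saturated chain carbon bound to an oxygen on an aromatic ring. In words, 2,6-dichlorophenyl comes in place of phenyl on a saturated chain carbon bound to an oxygen on an aromatic ring.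

Compound 1 also carries 2,6-dichlorobenzyl groups, and it gives > 50000 nM, which is a limit. Going by the values given here, no measured pair shows the size of this change on its own. The expectation is therefore for no step beyond the scatter in this assay, with no firm direction. The expected change is a 1.2-fold lower number from compound 2 to compound 4 (0.08 log units; within the scatter). For compound 4 the estimated value is 25000 nM, with an expected range of 9000 nM to 50000 nM.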

Compound 4, half-maximal inhibitory concentration: 16600 nM
For compound 4 the middle estimate is 1.5-fold (0.18 log units) above the measured one; measured number inside the range.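

In this assay, the change on this oxygen gives a 1.8-fold lower number from compound 2 to compound 4 (0.25 log units; within the scatter), so the two chlorine atoms of 2,6-dichlorobenzyl leave the number within the scatter of the plain benzyl compound. Going by these compounds alone, compound 1, which carries 2,6-dichlorobenzyl on both oxygens, stands at a limit and not at a number: the limit of > 50000 nM in this assay, at which 2 of the 4 values shown sit. The change at the second oxygen, hydrogen in place of 2,6-dichlorobenzyl, gives an at least 3.0-fold lower number from compound 1 to compound 4 (0.47 log units; beyond the scatter), and this is the first step beyond the scatter, although its true size cannot be read from a limit.

From the compounds shown here alone, it remains open whether a methoxy group in place of that hydroxyl would keep a measurable number. Going by these compounds, it is equally open whether a fluorobenzyl or pyridylmethyl group on the other oxygen would move the number beyond the scatter.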